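Chloro in place of carboxy on the shared core

The compounds below may be only part of what the source reports. "The series", "measured", "known", "first", "only" and "open" are said of these compounds alone.

Compound 1, with structure `Cn1c(-c2ccc(C(=O)O)cc2)nc2c(NC3CCCC3)ncnc21`, sits at the edge of what can be read in a functional assay on CHO cells for antagonist activity at adenosine receptor A2b (Homo sapiens), read by 33P incorporation, with a stated time of 20 min; a lower number here means a stronger inhibitor, a higher number a weaker inhibitor. In this assay compound 1 gives > 30000 nM, which is a limit of the measurement rather than a number. That is where compound 1 stands among the three values shown: the limit of > 30000 nM in this assay, at which 1 of the 3 values shown sits. Two related compounds carry a plain phenyl ring on the same core and were read as numbers. Compound 2, with structure `CCCn1c(-c2ccccc2)nc2c(NC3CCCCC3)ncnc21`, gives 5310 nM in this assay. Compound 3, with structure `CCn1c(-c2ccccc2)nc2c(N)ncnc21`, gives 3020 nM in this assay. The values of compound 2 and compound 3 lie within the usual scatter of each other.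

Compound 4, with structure `Cn1c(-c2ccc(Cl)cc2)nc2c(NC3CCCC3)ncnc21`, has not yet been measured. It differs from compound 1 in one place: chloro in place of carboxy on an aromatic carbon. Going by the values given here, no step between two measured compounds matches this change, so its size can only be expected, not read. Since the two phenyl compounds without any para group were read as numbers in the low-micromolar region, the expectation is that compound 4 moves toward stronger inhibition than compound 1, by a step of an at least 8.5-fold lower number from compound 1 to compound 4 (0.93 log units; beyond the scatter) in this assay. Compound 4 is estimated at 3500 nM, within a range from 800 nM to 15000 nM.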

Compound 4, inhibition constant: > 30000 nM
Compound 4 was reported as a limit; the forecaster's own chance of this, stated with the estimate: 15%; middle value at least 8.5-fold (0.93 log units) away from the limit.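

Going by these compounds alone, compound 1 and compound 4 are both limits in this assay rather than numbers, so no step between them can be read: the limit of > 30000 nM in this assay, at which 2 of the 4 values shown sit.

The compounds shown leave open how far either compound lies beyond that limit, and whether chloro in place of carboxy changes inhibition at all.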